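Shortening the Carbamate Chain and Epithelial Cell Cytotoxicity

The source may report more compounds than this note shows. Statements on the series, on what has been measured and on what is new or still open speak of the compounds shown alone.

Compound 2 `CCCCCCCCCCCCCCCCCCCCOC(=O)NC(CCC(=O)O)(CCC(=O)O)CCC(=O)O` has the smaller of the two numbers in an ADME assay on cells (Epithelial cell, Homo sapiens) for cytotoxicity, read by MTT assay (on this read-out lower numbers stand for an effect already at smaller amounts and higher numbers for an effect only at larger amounts of compound), giving 280000 nM, though this difference lies within the scatter. Compound 1 `CCCCCCCCCCCCCCCCCCOC(=O)NC(CCC(=O)O)(CCC(=O)O)CCC(=O)O` gives 350000 nM, and the step of a 1.3-fold lower number from compound 1 to compound 2 (0.10 log units; within the scatter) is within the scatter. Compound 3 `CCCCCCCCCCCCCCOC(=O)NC(CCC(=O)O)(CCC(=O)O)CCC(=O)O` has not yet been measured; it differs from compound 2 by hydrogen in place of hexyl on a saturated chain carbon, ten or more bonds along the chain from an oxygen next to a carbonyl group. Among the compounds with values here, only the step between compound 1 and compound 2 bears on this change, and it stayed within the scatter, so compound 3 is expected to show a small shift of a 1.6-fold higher number from compound 2 to compound 3 (0.21 log units; within the scatter), if any, toward a higher number. Compound 3 is therefore estimated at 450000 nM, with a range of 200000 nM to 1000000 nM.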

Compound 3, half-maximal effective concentration: 620000 nM
Beside the measured number, compound 3's estimate is 1.4-fold (0.14 log units) below it; low and high end bracket the measured number.
By their numbers in this assay, from the lowest: compounds 2, 1 and 3 (each within the scatter of the next, the first and the last beyond it).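

Taking hexyl off this saturated chain carbon gives the only step in the series that clears the scatter in this assay, with a 2.2-fold higher number from compound 2 to compound 3 (0.35 log units; beyond the scatter). The smaller change, hydrogen in place of butyl, stays within the scatter, with a 1.8-fold higher number from compound 1 to compound 3 (0.25 log units; within the scatter), so at this position only the larger shortening separates two compounds. Nothing measured here explains the shift.

From the compounds shown here alone, whether still shorter chains would keep raising the number remains open. So does how a chain ending in an amine or a hydroxyl group would read in this assay.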